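Removing the Trifluoromethyl Group from a Weak Cytotoxic Amidine

The compounds below may be only part of what the source reports. "The series", "measured", "known", "first", "only" and "open" are said of these compounds alone.

This series concerns cell-killing activity measured in a functional assay on HT-1080 cells (Homo sapiens) for cytotoxicity, read by MTT assay, with a stated time of 72 h; on this read-out higher numbers stand for weaker inhibition and lower numbers for stronger inhibition. Among the compounds with values here, compound 1, with the structure `N=C(Nc1cccc(C(F)(F)F)c1)c1cc2c(-c3ccccc3)n[nH]c2cn1`, is the only member with a numerical result: in this assay compound 1 gives 24600 nM, which on this scale counts as weak inhibition. A larger relative, compound 2 with the structure `COc1ccc(Cn2nc(-c3ccccc3)c3cc(C(=N)Nc4cccc(C(F)(F)F)c4)nc(Nc4cc(OC)c(OC)c(OC)c4)c32)cc1`, was also made, but for compound 2 the outcome in this assay is "not determined" (no result reported), so it provides no comparison point.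

Compound 3, with the structure `N=C(Nc1ccccc1)c1cc2c(-c3ccccc3)n[nH]c2cn1`, is not yet measured. Its difference from compound 1 is hydrogen in place of trifluoromethyl on an aromatic carbon. Within the data shown here, no pair of measured compounds shows the effect of such a change here, so the expectation rests on compound 1 alone, whose result in this assay is 24600 nM.

The step is expected to be small, most likely within the scatter or slightly toward weaker inhibition, giving an estimated 1.4-fold higher number from compound 1 to compound 3 (0.15 log units; within the scatter). Compound 3 is therefore estimated at 35000 nM, expected to fall between 12000 nM and 100000 nM.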

Compound 3, half-maximal inhibitory concentration: 22000 nM
Estimate against measurement, compound 3: 1.6-fold (0.20 log units) above, within the range that was stated.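

In this assay, replacing the trifluoromethyl group on the aromatic ring with a plain hydrogen gives a 1.1-fold lower number from compound 1 to compound 3 (0.05 log units; within the scatter), so losing these 4 heavy atoms leaves the read-out at the same level. Within the data shown here, this is the first direct comparison at this position, and it shows that, on this core, the weak cell-killing activity of compound 1 does not depend on the trifluoromethyl group: compound 3 lacks the group and cannot be told apart from compound 1 in this measurement. Nothing measured here explains why the two compounds match.

Going by these compounds, a single swap tests only one replacement at this aromatic carbon, so it remains open whether a different group there, such as an amine or a carboxylic acid, would shift the number beyond the usual scatter. On these data alone, it also remains open whether hydrogen and trifluoromethyl would still match on a version of the core carrying another addition, such as a longer chain.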